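Pyrazole chalcones: swapping the dichlorophenyl on compound 2

A few compounds are considered here, and "the series" means these few. Any claim that something is new, unique, unknown or untested is made for them only; others in the source may bear on it.

Three compounds of this series have been run in a functional assay on SN12C cells (Homo sapiens) for cytotoxicity, read by sulforhodamine B assay, with a stated time of 48 h, tested at 100 uM; on this read-out higher numbers stand for a weaker effect at the one concentration tested and lower numbers for a stronger effect. Compound 1 `COc1ccc(-c2cc(/C=C/C(=O)c3ccc(OC)c(OC)c3)[nH]n2)cc1` gives -86%, compound 3 `COc1ccc(-c2cc(/C=C/C(=O)c3ccc(N)cc3)[nH]n2)cc1OC` gives -90%, and compound 2 `COc1cc(-c2cc(/C=C/C(=O)c3ccc(Cl)c(Cl)c3)[nH]n2)cc(OC)c1OC` gives 11%. Compound 2 stands highest of the three numbers; its nearest neighbour is compound 1, lower by a gap beyond the scatter, and its furthest is compound 3, lower by a gap also beyond the scatter. Both compounds 1 and 3 therefore show a clearly stronger effect than compound 2 in this assay.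

Compound 4 `COc1ccc(C(=O)/C=C/c2cc(-c3cc(OC)c(OC)c(OC)c3)n[nH]2)cc1OC` is not yet measured. It differs from compound 2 in one place: 3,4-dimethoxyphenyl in place of 3,4-dichlorophenyl on a carbonyl carbon. Compound 1 also carries a 3,4-dimethoxyphenyl on a carbonyl carbon, and compound 1 gives -86%, so the dimethoxy pattern on that position is already seen alongside a strong effect in this series.

Among the measured compounds shown here, no step between measured compounds is known for this exact change. On the two values shown for compounds 1 and 2, the step from compound 2 to compound 4 is expected to be large and toward a stronger effect, a number 81 percentage points lower from compound 2 to compound 4 (beyond the scatter). Compound 4 is accordingly estimated at -70%, within a range from -95% to -20%.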

Compound 4, a percentage reported as activity, at one concentration (the size of the read-out at that concentration, not a potency): -86%
Compound 4: the middle estimate sits 16 percentage points above what was measured; measured number inside the range.
By their numbers in this assay, from the lowest: compounds 3, 1 and 4 (each within the scatter of the next); then compound 2.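

In this assay, among the compounds shown here, the single swap of 3,4-dichlorophenyl for 3,4-dimethoxyphenyl on a carbonyl carbon gives a step of a number 97 percentage points lower from compound 2 to compound 4 (beyond the scatter), so this one position alone can carry a change of this size with the rest of compound 2 unchanged. The earlier compounds shown here could not show this, since compound 1 and compound 3 each differ from compound 2 in more than one place. Compound 1 and compound 4 share the 3,4-dimethoxyphenyl on the carbonyl carbon and stand within the scatter of each other, though their other aryl groups differ; nothing available explains the step in terms of either group.

The compounds shown leave open whether the step follows from losing the two chlorines or from gaining the two methoxy groups, and an unsubstituted phenyl, a 4-chlorophenyl or a 4-methoxyphenyl on the carbonyl carbon would help separate the two readings. With every value taken at one concentration, they also leave open how compound 4 and compound 1 would compare in potency across a range of concentrations.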